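The compounds below may be only part of what the source reports. "The series", "measured", "known", "first", "only" and "open" are said of these compounds alone.

Compound 1 `COc1ccc(-c2cc(=O)c3c(OC)cc(OC)cc3n2Cc2ccccc2)cc1` was tested in a functional assay on SEM cells (Homo sapiens) for antiproliferative activity, with a stated time of 72 h; on this read-out higher numbers stand for an effect only at larger amounts of compound and lower numbers for an effect already at smaller amounts. There compound 1 gives only a limit, > 17300 nM, with no single number behind it. A related compound 2 `COc1ccc(-c2[nH]c3cc(OC)cc(OC)c3c(=O)c2I)cc1` carries no result in this assay, recorded as "not determined" (no result reported). So compound 1 stands at the limit (the limit of > 17300 nM in this assay, at which 1 of the 2 values shown sits), the weak end of what is shown. The unmeasured compound 3 `COc1ccc(-c2cc(=O)c3c(OC)cc(OC)cc3n2S(=O)(=O)c2ccc(C#N)cc2)cc1` differs from compound 1 by (4-cyanophenyl)sulfonyl in place of benzyl on an aromatic nitrogen. Among the measured compounds shown here, no measured step guides this change, so for compound 3 the expected step from compound 1 is small, an at least 1.1-fold lower number from compound 1 to compound 3 (0.06 log units; that floor lies within the scatter), with no clear direction beyond the scatter. Compound 3 is therefore estimated at 15000 nM, in a range from 2500 nM to 60000 nM.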

Compound 3, half-maximal effective concentration: 1300 nM
Estimate against measurement, compound 3: 12-fold (1.06 log units) above; the whole stated range lies above it.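

The group on this aromatic nitrogen clearly matters: in this assay, (4-cyanophenyl)sulfonyl in place of benzyl gives an at least 13-fold lower number from compound 1 to compound 3 (1.12 log units; beyond the scatter). Among the compounds shown here, this is the first readable change at this position, and it yields a single measured number where before there was none. The size of the step is a minimum, as compound 1 gives only a limit: the limit of > 17300 nM in this assay, at which 1 of the 3 values shown sits.

The compounds shown leave open whether the sulfonyl link or the nitrile accounts for the step. A plain phenylsulfonyl group or a chain ending in an amine on this nitrogen would help separate the two.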